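Swapping a sulfonyl group for an acetyl on compound 1

The source may hold more compounds than are shown below. What is called first, only, known or untested is meant among the compounds shown, and "the series" means these compounds.

Three compounds have been measured in an assay on isolated protein for inhibition of high affinity nerve growth factor receptor (Homo sapiens), read by 33P incorporation; on this read-out lower numbers stand for stronger inhibition and higher numbers for weaker inhibition:

Compound 1 `Nc1cc(NS(=O)(=O)c2ccc(F)cc2F)cc(-c2cnc3[nH]cc(-c4ccncc4)c3c2)c1` gives 2.97 nM
Compound 2 `COc1cccc(-c2cnc3[nH]cc(-c4ccncc4)c3c2)c1` gives 22.7 nM
Compound 3 `Nc1ccc(-c2cnc3[nH]cc(-c4ccncc4)c3c2)cc1` gives 25 nM

Among these three, compound 1 has the lowest number, and both other compounds stand well beyond the usual scatter above it. Going by the values given here, compound 2 and compound 3 carry only a small group on the ring attached to the shared core, while compound 1 carries a sulfonamide built on that ring, and this is the only compound in the set with a low single-digit reading.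

The next compound, compound 4 `CC(=O)Nc1cc(N)cc(-c2cnc3[nH]cc(-c4ccncc4)c3c2)c1`, keeps the amino group of compound 1 but changes the sulfonamide: acetyl in place of (2,4-difluorophenyl)sulfonyl on a nitrogen on an aromatic ring. Among the compounds with values here, no pair of measured compounds shows this kind of exchange, so the size of the step can only be guessed from what the simpler compounds show. In this assay the step of a 5.1-fold higher number from compound 1 to compound 4 (0.70 log units; beyond the scatter) is expected to be a rise in the number, moderate rather than small. This expectation rests on the simpler analogues: compound 2 gives 22.7 nM and compound 3 gives 25 nM, both without the larger group that compound 1 has. Compound 4 is therefore estimated at about 15 nM, with a likely range from 4 nM to 50 nM.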

Compound 4, half-maximal inhibitory concentration: 5.41 nM
Compound 4: the middle estimate sits 2.8-fold (0.44 log units) above what was measured, and the stated range covers the measured number.
By their numbers in this assay, from the lowest: compounds 1 and 4 (each within the scatter of the next); then compounds 2 and 3 (each within the scatter of the next).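

In this assay, putting acetyl in place of (2,4-difluorophenyl)sulfonyl on a nitrogen on an aromatic ring gives a 1.8-fold higher number from compound 1 to compound 4 (0.26 log units; within the scatter), so the two readings cannot be told apart. This exchange removes the six-membered aromatic ring and the sulfur and shrinks the group from 11 heavy atoms to 3, so at this position the large aryl sulfonyl group is not needed to keep a reading in this range. Nothing measured here explains why two such different groups give readings this close.

This single pair changes the ring and the linking group at once, so it cannot separate what each contributes: a methylsulfonyl group would keep the sulfonyl link without the ring, and a benzoyl group would keep a ring on a carbonyl link. On these data alone, whether this nitrogen needs any such group at all also remains open, and a plain amine in place of the acetamide would address that question.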